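The compounds below may be only part of what the source reports. "The series", "measured", "known", "first", "only" and "open" are said of these compounds alone.

Measured so far:
compound 1 `O[C@@H]1[C@@H](c2cn(Cc3ccccc3)nn2)NC[C@@H]1O` — 30%
compound 2 `O[C@@H]1[C@H](O)CN[C@@H]1c1cn(Cc2ccccc2)nn1` — "not active" (no number reported)

In an assay on isolated protein for inhibition of alpha-mannosidase (Canavalia ensiformis), with stated times of 5 min and 20 min, tested at 1 mM (a higher number here means more inhibition at the concentration tested (going by the name of the read-out), a lower number less inhibition), compound 1 gives 30%. Compound 2 is reported as "not active" (no number reported) in this assay, so it stands at no number, and the gap to compound 1 rests only on the fact that (the fact that compounds 1 and 2 differ only in the configuration as drawn). Compound 3 `O[C@@H]1[C@H](O)CN[C@H]1c1cn(Cc2ccccc2)nn1` is the next step: the two compounds have the same atoms and bonds and differ only in configuration as drawn: 1 of 3 stereo elements differ; a stereocentre at a saturated ring carbon is drawn R in compound 2 and S in compound 3. With compound 2 at no number, no step size is available; a shift in this assay of modest size, most likely toward some measurable inhibition, is expected, though a reading again below the reporting threshold cannot be excluded. Compound 3 is estimated at 15%, with a range of 0% to 40%.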

Compound 3, a percentage reported as inhibition, at one concentration (the size of the read-out at that concentration, not a potency): "not active" (no number reported)
Compound 3 has no reported number here, so the estimate cannot be set against anything.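

Compound 2 and compound 3 carry no number in this assay; no step can be read between them. Still open, on these data alone, is how far each lies from compound 1 at 30%, and which configuration change accounts for that gap.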